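The source may hold more compounds than are shown below. What is called first, only, known or untested is meant among the compounds shown, and "the series" means these compounds.

Measured compounds:
Compound 1, `CCN(CC)c1ccc2cc(C(=O)c3ccc(N4CCN(C(=O)CN5CCN(C(=O)/C=C/c6ccccc6)CC5)CC4)cc3)oc2c1`, in a functional assay on HCT-116 cells (Homo sapiens) for cytotoxicity, read by MTT assay, with a stated time of 48 h (on this read-out lower numbers stand for stronger inhibition and higher numbers for weaker inhibition), gives 6810 nM.
Compound 2, `CCN(CC)c1ccc2cc(C(=O)c3ccc(N4CCN(C(=O)CN5CCN(Cc6ccc(C#N)cc6)CC5)CC4)cc3)oc2c1`, in this assay gives only > 40000 nM.

The number for compound 2 is a limit of the assay and not a measured value, as recorded in the limit of > 40000 nM in this assay, at which 1 of the 2 values shown sits. Compound 2 therefore stands at the weak end of the two values shown, beyond the measurable range, whereas compound 1 gives a numeric reading. For the measured compounds named here, the one step between the measured pair, an at least 5.8-fold higher number from compound 1 to compound 2 (0.76 log units; beyond the scatter), went toward weaker inhibition.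

Compound 3, `CCOC(=O)CN1CCN(CC(=O)N2CCN(c3ccc(C(=O)c4cc5ccc(N(CC)CC)cc5o4)cc3)CC2)CC1`, differs from compound 2 by ethoxycarbonyl in place of 4-cyanophenyl on a saturated chain carbon bound to an amine nitrogen in a ring. Going by the values given here, no measured step exchanges these two groups, so the step from compound 1 to compound 2 bears on it only indirectly: it shows that a change at this ring nitrogen moved the read-out out of range, and compound 3 starts from that limit. Compound 3 is therefore expected to stay near the limit, with an estimate of 40000 nM (range 12000 nM to 120000 nM). The expected step of a number no higher from compound 2 to compound 3 (the limit leaves the size open) is none beyond the scatter.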

Compound 3, half-maximal inhibitory concentration: > 40000 nM
Compound 3 ended at the assay's limit (the forecaster's own chance of this, stated with the estimate: 60%); the middle value lies on the limit itself.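

In this assay the value of compound 3 is a limit of the assay and not a number, and the same holds for compound 2, so the step between these two cannot be read. The result does add a second replacement of (2-phenylethenyl)carbonyl on an amine nitrogen in a ring: (ethoxycarbonyl)methyl in its place gives an at least 5.8-fold higher number from compound 1 to compound 3 (0.76 log units; beyond the scatter), which lies beyond the scatter and goes toward weaker inhibition, as did the step with 4-cyanobenzyl. Of the three compounds, only compound 1 now gives a numeric reading, and two quite different replacements, one with an aromatic ring and one with no ring, end in the same place: the limit of > 40000 nM in this assay, at which 2 of the 3 values shown sit.

As far as these compounds go, how a benzoyl or an acetyl group on this amine nitrogen in a ring would read remains open, and with it whether the numeric reading of compound 1 goes with the carbonyl on that nitrogen or with the phenylethenyl part. Also open, from the compounds shown here alone, is any order of compound 2 and compound 3, whose actual values the limits do not give.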